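Amide series: ring methyl removal on the pyrazole

The compounds below may be only part of what the source reports. "The series", "measured", "known", "first", "only" and "open" are said of these compounds alone.

Measured compounds and their values in a functional assay on MV4-11 cells (Homo sapiens) for antiproliferative activity, with a stated time of 6 days, tested at 6.25 uM; a higher number here means a stronger effect of the compound at the concentration tested, a lower number a weaker effect:

compound 1 `CNC(=O)N1CCCc2ccc(NC(=O)c3cccc(-c4ccn(C)n4)c3)cc21`, 99.5%
compound 2 `CNC(=O)N1CCCc2ccc(NC(=O)c3cccc(-c4ccccc4)c3)cc21`, 1.39%
compound 3 `CNC(=O)N1CCCc2ccc(NC(=O)c3cccc(-c4cnn(C)c4)c3)cc21`, 93.5%

Compound 3 stands second highest of the three numbers in this assay; its nearest neighbour is compound 1, a number 6 percentage points lower from compound 1 to compound 3 (within the scatter), and its furthest is compound 2, a number 92.1 percentage points higher from compound 2 to compound 3 (beyond the scatter).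

Compound 4 `CNC(=O)N1CCCc2ccc(NC(=O)c3cccc(-c4cn[nH]c4)c3)cc21` differs from compound 3 by hydrogen in place of methyl on an aromatic nitrogen. Among the measured compounds shown here, no measured step changes a substituent on this aromatic nitrogen, so none bears directly on the change. The steps that come nearest are the two at the same aromatic carbon: the swap between the two pyrazolyl isomers, a number 6 percentage points lower from compound 1 to compound 3 (within the scatter), which was within the scatter, and the large loss on going to phenyl, a number 92.1 percentage points higher from compound 2 to compound 3 (beyond the scatter) in the other direction. Keeping the 1H-pyrazol-4-yl ring intact is taken to keep the effect largely in place, so the expected step of a number 8.5 percentage points lower from compound 3 to compound 4 (within the scatter) is small, if anything a slight decrease. For compound 4 the estimate is 85%, with a range from 55% to 99%.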

Compound 4, a percentage reported as inhibition, at one concentration (the size of the read-out at that concentration, not a potency): 77.7%
Beside the measured number, compound 4's estimate is 7.3 percentage points above it; the measured number falls inside the stated range.
By their numbers in this assay, from the lowest: compound 2; then compound 4; then compounds 3 and 1 (each within the scatter of the next).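

Taking the methyl off the aromatic nitrogen gives the first measured change at this ring nitrogen, and in this assay it carries a modest cost (a number 15.8 percentage points lower from compound 3 to compound 4 (beyond the scatter)). The 1H-pyrazol-4-yl ring still retains most of the large gain over phenyl (a number 76.3 percentage points higher from compound 2 to compound 4 (beyond the scatter)), so among these compounds the methyl is not required for a strong effect at the concentration tested, although its removal moves the number beyond the scatter. The step from the other methylated isomer is also modest (a number 21.8 percentage points lower from compound 1 to compound 4 (beyond the scatter)), and nothing available accounts for the loss on removing the methyl.

From the compounds shown here alone, whether an ethyl group or a longer chain ending in an amine on this aromatic nitrogen would hold the effect remains open. The same applies to a pyrazole carrying such a group in the isomeric arrangement of compound 1, and these single-concentration read-outs give no potency for any of the compounds.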